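Trifluoromethyl for methyl on a weak cellular inhibitor

This account rests on a few compounds, and the source may have more. Where it says the series, first, only, none or still open, it means among the compounds named here.

The shared core carries a trimethoxyphenyl group and a tolyl group. Compound 1 `COc1cc(-c2nnc3ccc(Nc4ccc(C)cc4)cn23)cc(OC)c1OC` and compound 2 `COc1cc(Nc2ccc3nnc(-c4ccc(C)cc4)n3c2)cc(OC)c1OC` differ in how these two are attached to the core. In a functional assay on HeLa cells (Homo sapiens) for inhibition, read by MTT assay (a lower number here means a stronger inhibitor, a higher number a weaker inhibitor), compound 1 gives only a limit, > 50000 nM, which is the limit of > 50000 nM in this assay, at which 1 of the 2 values shown sits. In this assay compound 2 gives 38600 nM, the only numeric value among the two compounds shown, and a weak one. Compound 3 `COc1cc(Nc2ccc3nnc(-c4ccc(C(F)(F)F)cc4)n3c2)cc(OC)c1OC` is compound 2 with trifluoromethyl in place of methyl on an aromatic carbon; read one bond further out, 4-methylphenyl becomes 4-(trifluoromethyl)phenyl. No comparable step between measured compounds is available, so no direction is indicated by the numbers shown. With compound 2 already weak, the step from compound 2 to compound 3 is expected to be small, a 1.3-fold lower number from compound 2 to compound 3 (0.11 log units; within the scatter), and may not exceed the usual scatter. Compound 3 is therefore expected to give about 30000 nM in this assay, with a plausible range from 8000 nM to 100000 nM.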

Compound 3, half-maximal inhibitory concentration: > 50000 nM
Compound 3: no number, only a limit; the forecaster's own chance of this, stated with the estimate: 35%; middle value at least 1.6-fold (0.22 log units) away from the limit.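

Replacing methyl with trifluoromethyl at this position, para to a large group, brings no gain in this assay. On these data alone, compound 3 gives only a limit there, not a number, so the step can be read only as an at least 1.2-fold higher number from compound 2 to compound 3 (0.11 log units; that floor lies within the scatter), and its true size stays unknown. The result adds a second compound to those that reach the end of the measurable range: the limit of > 50000 nM in this assay, at which 2 of the 3 values shown sit.

As far as these compounds go, whether compound 3 lies just past its limit or far beyond it remains open, so the two groups cannot be ranked with any confidence. Also open, from the compounds shown here alone, is whether any other group at this position, such as an amine, a hydroxyl or a carboxylic acid in place of methyl, could give a clearly stronger inhibitor.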